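This account rests on a few compounds, and the source may have more. Where it says the series, first, only, none or still open, it means among the compounds named here.

Of the compounds shown here, three sharing one core have been measured in a functional assay for inhibition of sodium/hydrogen exchanger (Oryctolagus cuniculus); a higher number here means a weaker inhibitor, a lower number a stronger inhibitor. Compound 1 `CCc1cc(Br)c(S(C)(=O)=O)cc1C(=O)N=C(N)N` gives 41 nM. Compound 2 `Cc1cc(-c2ccc(Cl)cc2Cl)c(S(C)(=O)=O)cc1C(=O)N=C(N)N` gives 42 nM, and compound 3 `Cc1cc(Sc2cccc(Cl)c2)c(S(C)(=O)=O)cc1C(=O)N=C(N)N` gives 37 nM. Compound 3 thus has the lowest of the three numbers, but its gaps to compound 1 and to compound 2 are both within the scatter, so no ordering among them can be claimed. Going by the values given here, the single one-point step measured so far, a 1.1-fold lower number from compound 2 to compound 3 (0.06 log units; within the scatter), shows that this exchange left the number essentially unchanged.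

Compound 4 `Cc1cc(N2CCCC(O)C2)c(S(C)(=O)=O)cc1C(=O)N=C(N)N` has not yet been measured. It differs from compound 3 in one place: 3-hydroxypiperidin-1-yl in place of (3-chlorophenyl)sulfanyl on an aromatic carbon. The entering group sits on an aromatic carbon ortho to a methylsulfonyl group and meta to a methyl group. Among the compounds with values here, the only measured step at this position is the flat one from compound 2 to compound 3, and compound 1, which carries a bromine atom there instead, falls in the same narrow band. Within the data shown here, nothing measured so far, however, involves a saturated ring bearing a hydroxyl at this position, so the basis for prediction is thin. The step from compound 3 to compound 4 is therefore expected to be a 1.6-fold higher number from compound 3 to compound 4 (0.21 log units; within the scatter), leaning toward a modestly higher number. Compound 4 is estimated at 60 nM, with a range from 20 nM to 180 nM.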

Compound 4, half-maximal inhibitory concentration: 30 nM
Compound 4: middle estimate off by 2.0-fold (0.30 log units), on the high side; the range from low to high includes it.
By their numbers in this assay, from the lowest: compounds 4, 3, 1 and 2 (each within the scatter of the next).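

At the aromatic carbon ortho to a methylsulfonyl group and meta to a methyl group, this assay now shows how a non-aromatic ring behaves: 3-hydroxypiperidin-1-yl in place of (3-chlorophenyl)sulfanyl gives a 1.2-fold lower number from compound 3 to compound 4 (0.09 log units; within the scatter) and in place of 2,4-dichlorophenyl gives a 1.4-fold lower number from compound 2 to compound 4 (0.15 log units; within the scatter) with both steps inside the usual scatter. Going by these compounds alone, until now, the only one-place exchange at this position had been between two groups that each carry a six-membered aromatic ring of carbon only. Compound 4 extends the flat result to a group of a different kind, a six-membered non-aromatic ring with a hetero atom and a hydroxyl, so at this position the number held across all three groups.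

On these data alone, it remains open whether an amine, a carboxylic acid or a longer alkyl chain on this carbon would stay in the same band, and whether plain piperidin-1-yl, without the hydroxyl, would do the same as compound 4. Nothing in the available data speaks to why these exchanges leave the number where it is.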